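Fluoro for Chloro, Repeated on a Second Core

A few compounds are considered here, and "the series" means these few. Any claim that something is new, unique, unknown or untested is made for them only; others in the source may bear on it.

Measured in a functional assay on K562 cells (Homo sapiens) for antiproliferative activity, read by MTT assay; on this read-out lower numbers stand for stronger inhibition and higher numbers for weaker inhibition:
compound 1 `N#Cc1c(F)c(Cl)c(C(C(=O)c2ccc(Cl)cc2)=C2NCCN2)c(C#N)c1F`: 1.6 ug/mL
compound 2 `N#Cc1c(F)c(F)c(C(C(=O)c2ccc(Cl)cc2)=C2NCCN2)c(C#N)c1F`: 1.8 ug/mL
compound 3 `N#Cc1c(F)c(Cl)c(C(C(=O)c2ccc(F)cc2)=C2NCCCCN2)c(C#N)c1F`: 2.1 ug/mL

Compound 2 arises from compound 1 by fluoro in place of chloro on an aromatic carbon, and in this assay this gives a 1.1-fold higher number from compound 1 to compound 2 (0.05 log units; within the scatter). Compound 3 shares the same change with compound 4 `N#Cc1c(F)c(F)c(C(C(=O)c2ccc(F)cc2)=C2NCCCCN2)c(C#N)c1F`, which differs from it by fluoro in place of chloro on an aromatic carbon; the surroundings of the place are identical word for word, so this is the same change. How the core of compound 3 differs from the core of compound 1 is not broken down here. Compound 4 is expected to show a 1.1-fold higher number from compound 3 to compound 4 (0.04 log units; within the scatter) in this assay, a step much like the earlier one, because a 1.1-fold higher number from compound 1 to compound 2 (0.05 log units; within the scatter). Compound 4 is therefore estimated at 2.3 ug/mL, with a range from 1.3 ug/mL to 4 ug/mL.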

Compound 4, half-maximal inhibitory concentration: 0.3 ug/mL
The estimate for compound 4 lay 7.7-fold (0.88 log units) above the measured number; the measured number lies below the stated range.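

In this assay, among these compounds, fluoro in place of chloro on an aromatic carbon did not behave as one transferable step, and the two cores part ways: the same change on two cores in this assay, a 1.1-fold higher number (0.05 log units; within the scatter) from compound 1 to compound 2 and a 7.0-fold lower number (0.85 log units; beyond the scatter) from compound 3 to compound 4, 7.9-fold (0.90 log units) apart, beyond the scatter of two such steps On the core of compound 3 the change gives a 7.0-fold lower number from compound 3 to compound 4 (0.85 log units; beyond the scatter), a clear gain in inhibition that has no counterpart on the core of compound 1. Among the compounds shown here, this shows that a step read on one core cannot simply be carried to the other, but it does not show which feature of the cores accounts for the gap, and each core offers only a single pair.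

The compounds shown leave open which of the differences between the two cores goes with the gap. They also leave open whether other groups at this place, such as bromo, methoxy or an amine, would diverge between the cores in the same way.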